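A Single Stereocentre Flipped at One Ring Carbon

The source may hold more compounds than are shown below. What is called first, only, known or untested is meant among the compounds shown, and "the series" means these compounds.

Compound 1 `CC1=C\C[C@H](O)/C=C/C(C)=C/[C@@H](NC(=O)[C@H](C)O)[C@@H](C)C(=O)/C(C)=C/C[C@H](O)\C=C\1` was tested in a functional assay on MCF7 cells (Homo sapiens) for cytotoxicity, read by MTT assay, with a stated time of 72 h (on this read-out higher numbers stand for weaker inhibition and lower numbers for stronger inhibition), where compound 1 gives 42800 nM. Compound 2 `CC(=O)C(=O)N[C@@H]1/C=C(C)/C=C/[C@@H](O)C/C=C(C)/C=C/[C@@H](O)C/C=C(\C)C(=O)[C@H]1C` gives in this assay > 100000 nM, which is a limit of the assay rather than a measured number (the limit of > 100000 nM in this assay, at which 1 of the 2 values shown sits). Compound 3 `CC(=O)C(=O)N[C@@H]1/C=C(C)/C=C/[C@@H](O)C/C=C(C)/C=C/[C@@H](O)C/C=C(\C)C(=O)[C@@H]1C` differs from compound 2 only in this way: the two compounds have the same atoms and bonds and differ only in configuration as drawn: 1 of 9 stereo elements differ; a stereocentre at a saturated ring carbon is drawn S in compound 2 and R in compound 3. Among the compounds with values here, no measured pair in this set changes configuration alone, so the size of such a step is unknown here. The step from compound 2 to compound 3 is expected to be an at least 1.1-fold lower number from compound 2 to compound 3 (0.04 log units; that floor lies within the scatter), not clearly beyond the scatter. Compound 3 is thus expected to give 90000 nM, between 25000 nM and 300000 nM.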

Compound 3, half-maximal inhibitory concentration: > 100000 nM
Compound 3: a limit, no number; the forecaster's own chance of this, stated with the estimate: 55%; middle value at least 1.1-fold (0.04 log units) from the limit.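

In this assay, within the data shown here, compound 3 gives a limit and not a number, as compound 2 does, so the step between them cannot be read and the flipped ring carbon shows no measurable effect: the limit of > 100000 nM in this assay, at which 2 of the 3 values shown sit. Acetyl in place of 1-hydroxyethyl on a carbonyl carbon gives an at least 2.3-fold higher number from compound 1 to compound 3 (0.36 log units; beyond the scatter), the first readable step in this set, and it goes toward weaker inhibition.

Still open, on these data alone, is what the same flip does with 1-hydroxyethyl on that carbonyl carbon. Also open, as far as these compounds go, is how an amine or a carboxylic acid would behave there in place of acetyl.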